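The compounds below may be only part of what the source reports. "The series", "measured", "known", "first", "only" and "open" are said of these compounds alone.

Measured in a functional assay on MIA PaCa-2 cells (Homo sapiens) for cytotoxicity, read by WST assay, with a stated time of 24 h; a lower number here means a stronger inhibitor, a higher number a weaker inhibitor:
Compound 1 `COc1ccc2[nH]cc(/C=C(\C#N)C(=O)c3c[nH]c4ccccc34)c2c1`: 21200 nM
Compound 2 `N#C/C(=C\c1c[nH]c2cc(F)ccc12)C(=O)c1c[nH]c2ccccc12`: 23500 nM
Compound 3 `COc1ccc2c(/C=C(\C#N)C(=O)c3c[nH]c4ccccc34)c[nH]c2c1`: 27500 nM

Compound 3 lies within the scatter of both compound 1 and compound 2, so the three values give no order. Compound 4 `N#C/C(=C\c1c[nH]c2ccccc12)C(=O)c1c[nH]c2ccccc12` has hydrogen in place of methoxy on an aromatic carbon. For the measured compounds named here, the one measured step that exchanges a group on this carbon is a 1.2-fold higher number from compound 2 to compound 3 (0.07 log units; within the scatter) and it gives no signal to scale from. No change beyond the scatter is therefore expected in this assay, though hydrogen itself has not been tested here. For compound 4 the estimated value is 24000 nM, with an expected range of 12000 nM to 46000 nM as its bounds. The expected change is a 1.1-fold lower number from compound 3 to compound 4 (0.06 log units; within the scatter), in no firm direction.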

Compound 4, half-maximal inhibitory concentration: 17900 nM
Compound 4: middle estimate off by 1.3-fold (0.13 log units), on the high side; the range from low to high includes it.
By their numbers in this assay, from the lowest: compounds 4, 1, 2 and 3 (each within the scatter of the next).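

In this assay hydrogen on this aromatic carbon gives a 1.5-fold lower number from compound 3 to compound 4 (0.19 log units; within the scatter) in place of methoxy and a 1.3-fold lower number from compound 2 to compound 4 (0.12 log units; within the scatter) in place of fluoro. Hydrogen in place of methoxy at another carbon of the same ring gives a 1.2-fold lower number from compound 1 to compound 4 (0.07 log units; within the scatter) and likewise separates nothing, so neither methoxy nor fluoro is shown to matter here. No evidence on hand bears on this result.

Open, on these data alone, is whether an amine or a carboxylic acid on this carbon would move the number beyond the scatter in this assay at all. Also open, as far as these compounds go, is whether any change elsewhere on the shared core would do so.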